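Dropping One Fluoro: From Compound 1 to Compound 3

The source may hold more compounds than are shown below. What is called first, only, known or untested is meant among the compounds shown, and "the series" means these compounds.

Compound 1, `O=C(N/N=C/c1ccc(-c2ccc(F)cc2F)o1)c1ccccc1O`, was tested in a functional assay on BGC-823 cells (Homo sapiens) for antiproliferative activity, read by sulforhodamine B assay, with a stated time of 48 h (on this read-out higher numbers stand for weaker inhibition and lower numbers for stronger inhibition), where compound 1 gives 46600 nM. Compound 2, `COc1ccccc1/C=N/NC(=O)c1ccc(-c2ccc(F)cc2F)o1`, in this assay gives 81600 nM. These two numbers lie within the scatter of each other, so neither compound can be called the stronger inhibitor; compound 1 simply holds the lower of the two numbers.

Compound 3, `O=C(N/N=C/c1ccc(-c2ccc(F)cc2)o1)c1ccccc1O`, has not yet been measured. It differs from compound 1 in one place: hydrogen in place of fluoro on an aromatic carbon. Going by the values given here, no pair of measured compounds shows what such a change does in this assay, so no measured step can guide the expectation, and both measured numbers sit far from strong inhibition. Compound 1 gives 46600 nM in this assay, and from there the expected step is a 1.2-fold higher number from compound 1 to compound 3 (0.07 log units; within the scatter), not beyond the scatter in either direction. The estimated value for compound 3 is 55000 nM, with a range from 20000 nM to 150000 nM.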

Compound 3, half-maximal inhibitory concentration: 9500 nM
Compound 3: middle estimate off by 5.8-fold (0.76 log units), on the high side, and the stated range ends above it.
By their numbers in this assay, from the lowest: compound 3; then compounds 1 and 2 (each within the scatter of the next).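

Going from 2,4-difluorophenyl to 4-fluorophenyl gives a 4.9-fold lower number from compound 1 to compound 3 (0.69 log units; beyond the scatter) in this assay, the first measured step in this series to lie beyond the scatter. It shows that this aromatic carbon, ortho to a large group and meta to a fluoro group, is not indifferent to what it carries: here, hydrogen gives stronger inhibition than fluoro, though the result rests on a single pair of compounds. No measurement shown here gives a reason for this step.

From the compounds shown here alone, whether chloro, a methyl group or an amine on this carbon would extend the gain or undo it remains open. Going by these compounds, it is also open whether removing the remaining fluoro group would move the number further, or whether the same change would have a similar effect on compound 2.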